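Amino Substitution on a Fused Core: Toxicity Still Unseen

The source may hold more compounds than are shown below. What is called first, only, known or untested is meant among the compounds shown, and "the series" means these compounds.

Compound 1, `ClCc1ccc(Cn2cnc3c(Cl)ncnc32)cc1`: > 100000 nM
Compound 2, `Nc1nc(Cl)c2ncn(Cc3ccc(CCl)cc3)c2n1`: > 100000 nM
Compound 3, `ClCc1ccccc1Cn1cnc2c(Cl)ncnc21`: > 100000 nM

These three compounds were tested in a functional assay on MCF7 cells (Homo sapiens) for cytotoxicity, read by sulforhodamine B assay, with a stated time of 48 h; a higher number here means that more compound is tolerated, a lower number that less compound is tolerated. In this assay compound 1 gives > 100000 nM, which is a limit of the measurement, not a number. Compound 2 likewise gives only a limit, > 100000 nM. Compound 3 also gives only a limit, > 100000 nM. All three sit at the limit of > 100000 nM in this assay, at which 3 of the 3 values shown sit.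

Compound 2 differs from compound 1 by amino in place of hydrogen on an aromatic carbon. The step that the two limits leave unreadable from compound 1 to compound 2 cannot be read, as both ends are limits. Compound 4, `Nc1nc(Cl)c2ncn(Cc3ccccc3CCl)c2n1`, is not yet measured; it differs from compound 3 by the same change, (amino in place of hydrogen on an aromatic carbon). The cores of compound 1 and compound 3 have the same atoms joined differently; the difference between the two cores is not broken down here.

Because the matching step that the two limits leave unreadable from compound 1 to compound 2 left both values at the limit, a step that the limit leaves unreadable from compound 3 to compound 4 is expected here. Compound 4 is therefore expected to give 150000 nM, somewhere between 70000 nM and 500000 nM, most likely again only a limit.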

Compound 4, concentration lethal to 50% of the cells: 87100 nM
The estimate for compound 4 lay 1.7-fold (0.24 log units) above the measured number; the range from low to high includes it.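

Putting amino in place of hydrogen on an aromatic carbon of this core gives, in this assay, an at least 1.1-fold lower number from compound 3 to compound 4 (0.05 log units; that floor lies within the scatter). This shows that compound 4, at 87100 nM, is the only compound shown with a value that can be read as a number, but the change itself cannot be said to lower the number, since the smallest step the data allow lies within the usual scatter and the true size of the step stays unknown. The same change on the core of compound 1 cannot be read at all, as both ends there are limits, so carrying it from one core to the other is neither confirmed nor ruled out, and most of the values shown are still limits: the limit of > 100000 nM in this assay, at which 3 of the 4 values shown sit.

The compounds shown leave open whether a different group in the place of amino, such as a hydroxyl or a methylamino group, would give a step clearly beyond the scatter. They also leave open what happens when the chloro group on the same ring is replaced by a methoxy group.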